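This account rests on a few compounds, and the source may have more. Where it says the series, first, only, none or still open, it means among the compounds named here.

Compound 1, `CCCCC(O)c1cccc(NC(=O)NCCCCl)c1`: 19000 nM
Compound 2, `CC(C)(C)c1ccc(CNC(=O)NC(=O)CCl)cc1`: 7100 nM

Both were tested in a functional assay on HT-29 cells (Homo sapiens) for antiproliferative activity, with a stated time of 48 h; a lower number here means a stronger inhibitor, a higher number a weaker inhibitor. Compound 2 stands at the lower of the two numbers, and compound 1 gives a number higher by more than the usual scatter. Compound 3, `CC(C)(C)c1ccc(CNC(=O)CCCCl)cc1`, differs from compound 2 by one change: 3-chloropropyl in place of ((chloromethyl)carbonyl)amino on a carbonyl carbon. Among the compounds with values here, no measured pair shows this kind of exchange, so its effect is unknown from the numbers at hand. In this assay the expected step is a 2.8-fold higher number from compound 2 to compound 3 (0.45 log units; beyond the scatter), toward a weaker inhibitor. The estimate for compound 3 is 20000 nM, with a range from 5000 nM to 80000 nM.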

Compound 3, half-maximal inhibitory concentration: 72000 nM
The estimate for compound 3 lay 3.6-fold (0.56 log units) below the measured number; measured number inside the range.
By their numbers in this assay, from the lowest: compound 2; then compound 1; then compound 3.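

In this assay putting 3-chloropropyl in place of ((chloromethyl)carbonyl)amino on a carbonyl carbon gives a 10-fold higher number from compound 2 to compound 3 (1.01 log units; beyond the scatter) and shows that this position responds strongly to the exchange. The change removes the hydrogen-bond donor and acceptor of the leaving group, yet it also alters the chain, and one exchange cannot separate these differences. Nothing available explains the loss.

As far as these compounds go, it remains open whether the chlorine is needed, which a plain propyl group would test. A simple amine on the same carbonyl carbon would show whether the nitrogen alone matters.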